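The source may hold more compounds than are shown below. What is called first, only, known or untested is meant among the compounds shown, and "the series" means these compounds.

In an assay for inhibition of Fatty-acid amide hydrolase 1 (Rattus norvegicus) (a higher number here means a weaker inhibitor, a lower number a stronger inhibitor), three compounds sharing one core have been measured. Compound 1 `O=C(CCc1ccc(-c2ccccc2)cc1)c1ncc(-c2ccncc2)o1` gives 2.3 nM. Compound 2 `COC(=O)c1ccc(-c2cnc(C(=O)CCc3ccc(-c4ccccc4)cc3)o2)nc1` gives 2.2 nM, and the step of a 1.0-fold lower number from compound 1 to compound 2 (0.02 log units; within the scatter) lies within the scatter. Compound 3 `COC(=O)c1ccc(-c2cnc(C(=O)CCc3ccc(-c4ccccc4)cc3)o2)cn1` gives 0.6 nM, the lowest of the three numbers; the steps of a 3.8-fold lower number from compound 1 to compound 3 (0.58 log units; beyond the scatter) and a 3.7-fold lower number from compound 2 to compound 3 (0.56 log units; beyond the scatter) are both beyond the scatter, though modest in size.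

Compound 4 `CN(C)C(=O)c1cnc(C(=O)CCc2ccc(-c3ccccc3)cc2)o1` has not yet been measured in this assay. It differs from compound 3 in one place: dimethylcarbamoyl in place of 6-(methoxycarbonyl)pyridin-3-yl on an aromatic carbon. Among the measured compounds shown here, none of the measured steps covers a change of this kind. Each of them exchanges one six-membered aromatic ring with one hetero atom for another at the same aromatic carbon, whereas here the 6-(methoxycarbonyl)pyridin-3-yl leaves and dimethylcarbamoyl, a group with no ring, enters. The measured steps only show that this position accepts variation of the ring, with consequences ranging from the step of a 1.0-fold lower number from compound 1 to compound 2 (0.02 log units; within the scatter) to the step of a 3.7-fold lower number from compound 2 to compound 3 (0.56 log units; beyond the scatter).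

For the measured compounds named here, with no direct precedent, compound 4 is expected to give a higher number than compound 3, a step estimated at a 10-fold higher number from compound 3 to compound 4 (1.00 log units; beyond the scatter), though a step within the scatter cannot be excluded. The estimate for compound 4 in this assay is 6 nM, with a range from 1.5 nM to 25 nM.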

Compound 4, inhibition constant: 3 nM
Estimate against measurement, compound 4: 2.0-fold (0.30 log units) above; low and high end bracket the measured number.
By their numbers in this assay, from the lowest: compound 3; then compounds 2, 1 and 4 (each within the scatter of the next).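

In this assay, the aromatic carbon next to the ring oxygen proves to accept a group with no ring at all: the steps of a 1.3-fold higher number from compound 1 to compound 4 (0.12 log units; within the scatter) and a 1.4-fold higher number from compound 2 to compound 4 (0.13 log units; within the scatter) both lie within the scatter, so dimethylcarbamoyl cannot be told apart from pyridin-4-yl or 5-(methoxycarbonyl)pyridin-2-yl here. Among the four compounds, only 6-(methoxycarbonyl)pyridin-3-yl stands apart from the others, and the step of a 5.0-fold higher number from compound 3 to compound 4 (0.70 log units; beyond the scatter) is beyond the scatter but modest, so a ring at this position is not required, and replacing this particular ring costs only a limited amount. Nothing available here explains why the loss of the ring changes the number so little.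

The compounds shown leave open whether this tolerance belongs to dimethylcarbamoyl in particular or extends to other groups without a ring on this carbon, such as a methyl ester, a carboxylic acid, an amine or a longer alkyl chain. They also leave open whether a methoxycarbonyl group placed directly on this carbon, without the ring that carries it in compound 3, would give a number closer to that of compound 3 or to those of the other three.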